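The source may report more compounds than this note shows. Statements on the series, on what has been measured and on what is new or still open speak of the compounds shown alone.

Compound 3 `O=C(CC1c2ccccc2N=C(N2CCCCC2)N1c1ccccc1)OCc1ccccc1` stands second highest of the three measured compounds in a functional assay on cells (Oocyte) for inhibition of Voltage-dependent T-type calcium channel subunit alpha-1H (Homo sapiens), tested at 100 uM (on this read-out lower numbers stand for less inhibition and higher numbers for more inhibition at the one concentration tested (going by the name of the read-out)), giving 15.6%. Its nearest neighbour is compound 1 `O=C(O)CC1c2ccccc2N=C(N2CCCCC2)N1c1ccccc1`, which gives 8%; the gap a number 7.6 percentage points higher from compound 1 to compound 3 (within the scatter) is within the scatter. Furthest off is compound 2 `O=C(CC1c2ccccc2N=C(N2CCCCC2)N1c1ccccc1)NCc1ccccc1`, which gives 77%. Compound 4 `Nc1ccc(CNC(=O)CC2c3ccccc3N=C(N3CCCCC3)N2c2ccccc2)cc1` differs from compound 3 by (4-aminobenzyl)amino in place of benzyloxy on a carbonyl carbon. For the measured compounds named here, the steps that bear on this are a number 61.4 percentage points lower from compound 2 to compound 3 (beyond the scatter) and a number 69 percentage points higher from compound 1 to compound 2 (beyond the scatter), both large, and both place benzylamino on the carbonyl carbon far above benzyloxy or hydroxy on that carbon. Going by the values given here, the added amino on the ring has no precedent among the measured compounds. For compound 4 a large rise, a number 54.4 percentage points higher from compound 3 to compound 4 (beyond the scatter), is therefore expected. Compound 4 is estimated at 70%, with a range from 45% to 90%.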

Compound 4, a percentage reported as inhibition, at one concentration (the size of the read-out at that concentration, not a potency): 66.8%
For compound 4 the middle estimate is 3.2 percentage points above the measured one; the range from low to high includes it.
By their numbers in this assay, from the lowest: compounds 1 and 3 (each within the scatter of the next); then compound 4; then compound 2.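

In this assay, the carbonyl carbon keeps its strong preference for a benzylic amino group once the ring is substituted, with a number 51.2 percentage points higher from compound 3 to compound 4 (beyond the scatter) and a number 58.8 percentage points higher from compound 1 to compound 4 (beyond the scatter). Adding the amino group to the aromatic carbon gives a modest drop that stays beyond the scatter, a number 10.2 percentage points lower from compound 2 to compound 4 (beyond the scatter), so this is the first ring change seen and it leaves most of the gain intact. Nothing available explains either step.

Going by these compounds, whether a methoxy group or a carboxylic acid in place of that amino group would hold this level remains open. So does the effect of a longer chain, such as 2-phenylethylamino, on the carbonyl carbon.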